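A few compounds are considered here, and "the series" means these few. Any claim that something is new, unique, unknown or untested is made for them only; others in the source may bear on it.

Three related compounds have been tested in a functional assay on MDA-MB-231 cells (Homo sapiens) for antiproliferative activity, with a stated time of 5 days; on this read-out lower numbers stand for stronger inhibition and higher numbers for weaker inhibition. Compound 1 `COc1ccc(-n2nc(-c3ccc4ccccc4c3)nc2N2C(=O)COC23C=CC(=O)C=C3)cc1` gives 60 nM, compound 2 `CC1OC2(C=CC(=O)C=C2)N(c2nc(-c3ccc4ccccc4c3)nn2-c2ccc3ccccc3c2)C1=O` gives 60 nM and compound 3 `Cc1ccc(-n2nc(-c3ccc4ccccc4c3)nc2N2C(=O)COC23C=CC(=O)C=C3)cc1` gives 30 nM, so compound 3 sits within the usual scatter of both others and the three cannot be told apart.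

Compound 4 `O=C1C=CC2(C=C1)OCC(=O)N2c1nc(-c2ccc3ccccc3c2)nn1-c1ccc2ccccc2c1` differs from compound 3 in one place: naphthalen-2-yl in place of 4-methylphenyl on an aromatic nitrogen. Within the data shown here, the only measured single-place step, a 2.0-fold lower number from compound 1 to compound 3 (0.30 log units; within the scatter), puts methyl in place of methoxy on an aromatic carbon and stays within the scatter. Compound 2 also carries naphthalen-2-yl on that aromatic nitrogen, along with an extra methyl on the core, and it gives 60 nM. No step beyond the scatter is therefore expected in this assay, though any drift would more likely be towards a somewhat higher number. The expected change is small, a 1.5-fold higher number from compound 3 to compound 4 (0.18 log units; within the scatter). For compound 4 the estimated value is 45 nM, with an expected range from 18 nM to 110 nM.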

Compound 4, half-maximal inhibitory concentration: 50 nM
For compound 4 the middle estimate is 1.1-fold (0.05 log units) below the measured one; low and high end bracket the measured number.
By their numbers in this assay, from the lowest: compounds 3, 4, 1 and 2 (each within the scatter of the next).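

In this assay, the larger naphthalen-2-yl group, with 10 heavy atoms against 7 in 4-methylphenyl, gives a 1.7-fold higher number from compound 3 to compound 4 (0.22 log units; within the scatter) when it takes the place of that group on the aromatic nitrogen. Among these compounds, its replacement of 4-methoxyphenyl at the same nitrogen gives a 1.2-fold lower number from compound 1 to compound 4 (0.08 log units; within the scatter), so a second fused carbon ring on this nitrogen produces no step that can be told from the scatter. With naphthalen-2-yl in place, removing the methyl from the saturated ring carbon gives a 1.2-fold lower number from compound 2 to compound 4 (0.08 log units; within the scatter), so that methyl also makes no readable difference in this pair.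

No supporting measurement bears on why these numbers stay so close. Still open, as far as these compounds go, is how this aromatic nitrogen would respond to a substituent such as an amine or a carboxylic acid on its aromatic ring, or to a longer chain in place of that ring.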